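Shortening the Sulfonamide Nitrogen Chain from Propyl to Methyl

A few compounds are considered here, and "the series" means these few. Any claim that something is new, unique, unknown or untested is made for them only; others in the source may bear on it.

Compound 3 `CCCN(Cc1ccc(N2CCN(C(C)=O)CC2)cc1)S(=O)(=O)Cc1ccccc1` gives 40000 nM in a physicochemical assay for solubility, in phosphate buffer, measured as kinetic solubility, with a stated time of 24 h, at pH 7.4; on this read-out higher numbers stand for higher solubility and lower numbers for lower solubility. Going by the values given here, compound 1 `CC(C)CN(Cc1ccc(N2CCN(C)CC2)cc1)S(=O)(=O)Cc1ccccc1` gives 60000 nM in this assay, and this value lies within the usual scatter of the one for compound 3. Compound 2 `CC(C)CN(Cc1ccc(N2CCC(C(N)=O)CC2)cc1)S(=O)(=O)Cc1ccccc1` gives <= 1000 nM, which is a limit of the assay and not a number. So compound 3 has only one measured number to compare with, and the two cannot be told apart.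

The next compound, compound 4 `CC(=O)N1CCN(c2ccc(CN(C)S(=O)(=O)Cc3ccccc3)cc2)CC1`, keeps the rest of compound 3 and changes one chain: hydrogen in place of ethyl on a saturated chain carbon bound to a sulfonamide nitrogen. In words, this is hydrogen in place of ethyl on a saturated chain carbon bound to a sulfonamide nitrogen, which also reads as propyl to methyl.

Among the compounds with values here, the only measured step, an at least 60-fold lower number from compound 1 to compound 2 (1.77 log units; beyond the scatter), is large. However, it is 4-carbamoylpiperidin-1-yl in place of 4-methylpiperazin-1-yl on an aromatic carbon, a different place from this chain. Within the data shown here, no measured step touches the chain, so that size does not carry over, and the expectation starts from compound 3 at 40000 nM.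

No change beyond the scatter is expected, and the estimated step is a 1.3-fold higher number from compound 3 to compound 4 (0.10 log units; within the scatter). For compound 4 the expected value is 50000 nM, with an estimated range from 15000 nM to 130000 nM.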

Compound 4, solubility: 7000 nM
Beside the measured number, compound 4's estimate is 7.1-fold (0.85 log units) above it, outside the stated range (below it).
By their numbers in this assay, from the lowest: compound 4; then compounds 3 and 1 (each within the scatter of the next). At a limit, below all of these: compound 2.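

Hydrogen in place of ethyl on a saturated chain carbon bound to a sulfonamide nitrogen, which also reads as propyl to methyl, gives in this assay a 5.7-fold lower number from compound 3 to compound 4 (0.76 log units; beyond the scatter) and so lies beyond the usual scatter of repeat measurements. Going by these compounds alone, this is the first measured step at this chain, so the number responds to a change here as well as to the change on the aromatic carbon, which gave an at least 60-fold lower number from compound 1 to compound 2 (1.77 log units; beyond the scatter) in a different place and on a different chain. What is shown gives no reason for this step, and the only limit in the set belongs to a compound outside this pair, so it does not bear on the result.

The compounds shown leave open whether the number follows chain length in a steady way, or whether only the loss of the propyl chain matters, and a butyl chain or an ethyl chain in this place would help to tell these apart. They also leave open whether the same change on the chain gives a step of similar size when the acetylated piperazine is replaced by another group, such as a morpholine.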